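Estimating the Mirror Image: Solubility of Compound 4

The compounds below may be only part of what the source reports. "The series", "measured", "known", "first", "only" and "open" are said of these compounds alone.

Measured in a physicochemical assay for solubility, read by HPLC, in phosphate buffer, measured as thermodynamic solubility, with a stated time of 24 h, at pH 6.8; a higher number here means a more soluble compound, a lower number a less soluble compound:
Compound 1 `C=CC(=O)N1CC[C@H](N2C(=O)N(C3CCCC3)Cc3cnc(Nc4ccc(N5CCN(C)CC5)cc4OC)nc32)C1`: 250 ug/mL
Compound 2 `C=CC(=O)N1CC[C@H](N2C(=O)N(c3ccccc3)Cc3cnc(Nc4ccc(N5CCN(C)CC5)cc4OC)nc32)C1`: 1540 ug/mL
Compound 3 `C=CC(=O)N1CCC[C@@H](N2C(=O)N(Cc3ccccc3)Cc3cnc(Nc4ccc(N5CCN(C)CC5)cc4OC)nc32)C1`: 142 ug/mL

Compound 3 has the lowest of the three numbers in this assay. Its nearest neighbour is compound 1, whose number lies within the scatter of repeated measurements, so the two cannot be ordered. Its furthest neighbour is compound 2, which lies beyond the scatter. For the measured compounds named here, the only single-point step among the measured compounds is a 6.2-fold higher number from compound 1 to compound 2 (0.79 log units; beyond the scatter), where a phenyl replaces a cyclopentyl on an amide-type nitrogen in a ring.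

Compound 4 `C=CC(=O)N1CCC[C@H](N2C(=O)N(Cc3ccccc3)Cc3cnc(Nc4ccc(N5CCN(C)CC5)cc4OC)nc32)C1` is the compound still to be measured. Compared with compound 3, (the two compounds have the same atoms and bonds and differ only in configuration as drawn: 1 of 1 stereo elements differ; a stereocentre at a saturated ring carbon is drawn R in compound 3 and S in compound 4).

Going by the values given here, no measured step bears on this change. Among the compounds with values here, the one step recorded exchanges a group for another group, while the step from compound 3 to compound 4 exchanges nothing and only inverts the drawn configuration at a saturated ring carbon. Within the data shown here, with no comparable precedent, the expectation is a step that stays within the scatter, in no particular direction. Compound 4 is therefore expected to give 150 ug/mL in this assay, within a range of 60 ug/mL to 380 ug/mL. This estimate means a 1.1-fold higher number from compound 3 to compound 4 (0.02 log units; within the scatter).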

Compound 4, solubility: 129 ug/mL
Estimate against measurement, compound 4: 1.2-fold (0.07 log units) above; measured number inside the range.
By their numbers in this assay, from the lowest: compounds 4, 3 and 1 (each within the scatter of the next); then compound 2.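

In this assay, the inversion at the saturated ring carbon gives a 1.1-fold lower number from compound 3 to compound 4 (0.04 log units; within the scatter), so the two compounds cannot be ordered. This pair is the first among the compounds shown in which the drawn configuration at this carbon can be read alone, without a second change in the structure, and the comparison rests on one fact: the fact that compounds 3 and 4 differ only in the configuration as drawn. For this one pair, with the group on the amide-type nitrogen in a ring held constant, the configuration as drawn makes no difference that can be told from the usual scatter of the measurement, unlike the step that exchanged cyclopentyl for phenyl at that nitrogen, a 6.2-fold higher number from compound 1 to compound 2 (0.79 log units; beyond the scatter).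

The compounds shown do not tell whether the same inversion would stay as small with phenyl or cyclopentyl on the amide-type nitrogen in a ring, since each of those groups appears here in one configuration only. They also leave open how a pyridyl group, a primary amine or a carboxylic acid at that nitrogen would read in this assay, and whether either configuration would hold up there.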